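Chain homologation on a fluorinated methoxybenzylamide core

A few compounds are considered here, and "the series" means these few. Any claim that something is new, unique, unknown or untested is made for them only; others in the source may bear on it.

Measured so far in an assay on isolated protein for agonist activity at melatonin receptor type 1C (Xenopus laevis), read by spectrophotometry; a lower number here means that less compound is needed, a higher number that more compound is needed for the effect:

Compound 1, `CCC(=O)NCc1cc(OC)ccc1F`: 2400 nM
Compound 2, `CCCC(=O)NCc1cc(OC)ccc1F`: 1350 nM
Compound 3, `COc1cc(CNC(C)=O)ccc1F`: 2090 nM

The three measured compounds all fall close together, and no one of them can be called the most or least active. Compound 2 differs from compound 1 by methyl in place of hydrogen on a saturated chain carbon, two bonds along the chain from a carbonyl carbon, and that step gave a 1.8-fold lower number from compound 1 to compound 2 (0.25 log units; within the scatter). Compound 3 sits near compound 1; the difference between the cores of compound 1 and compound 3 is not broken down here, so their values are simply set side by side.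

Compound 4, `CCC(=O)NCc1ccc(F)c(OC)c1`, has not yet been measured in this assay. It differs from compound 3 by methyl in place of hydrogen on a saturated chain carbon bound to a carbonyl carbon. Among the compounds with values here, this is the same kind of change as the one from compound 1 to compound 2, though not placed identically: there the methyl entered on a saturated chain carbon two bonds along the chain from a carbonyl carbon, here it enters on a saturated chain carbon bound to a carbonyl carbon.

Because the earlier step gave a 1.8-fold lower number from compound 1 to compound 2 (0.25 log units; within the scatter), compound 4 is expected to show a step of similar, modest size, a 1.5-fold lower number from compound 3 to compound 4 (0.17 log units; within the scatter). Compound 4 is therefore estimated at 1400 nM, most likely between 600 nM and 3500 nM.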

Compound 4, half-maximal effective concentration: 2880 nM
The estimate for compound 4 lay 2.1-fold (0.31 log units) below the measured number; low and high end bracket the measured number.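

In this assay, the change from acetamido to propanoylamino gave a 1.4-fold higher number from compound 3 to compound 4 (0.14 log units; within the scatter). Set beside the earlier methyl step on the other core, this result does not separate the two cores: the same change on two cores in this assay, a 1.8-fold lower number (0.25 log units; within the scatter) from compound 1 to compound 2 and a 1.4-fold higher number (0.14 log units; within the scatter) from compound 3 to compound 4, 2.4-fold (0.39 log units) apart, within the scatter of two such steps

The change therefore shows no sign of depending on the core, but this does not show that it carries a real effect from one core to the other: each step lies within the scatter on its own, and the methyl enters on a saturated chain carbon bound to a carbonyl carbon in one case and two bonds along the chain from a carbonyl carbon in the other.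

The compounds shown leave open whether a longer chain, a branched chain such as isopropyl or a cyclopropyl group on the carbonyl would move the number beyond the scatter on either core. They also leave open what a urea in place of the amide, or an ethoxy group or a hydroxyl group in place of the methoxy group, would do in this assay.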